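Changing the amide side chain of compound 3

The source may report more compounds than this note shows. Statements on the series, on what has been measured and on what is new or still open speak of the compounds shown alone.

In a functional assay on EBC-1 cells (Homo sapiens) for antiproliferative activity, with a stated time of 72 h (on this read-out lower numbers stand for stronger inhibition and higher numbers for weaker inhibition), compound 1 `Cn1cc(-c2cc(Cl)c3ncc(Cc4ccc5ncccc5c4)n3c2)cn1` stands at "not determined" (no result reported) with no number to use. Compound 2 `N#Cc1ccc(-c2cc(F)c3ncc(Cc4ccc5ncccc5c4)n3c2)cc1F` gives 145 nM and compound 3 `CN(C)CCNC(=O)c1ccc(-c2cc(F)c3ncc(Cc4ccc5ncccc5c4)n3c2)cc1F` gives 49 nM as the lower of the two numbers. Compound 4 `O=C(NCc1cc(F)cc(F)c1)c1ccc(-c2cc(F)c3ncc(Cc4ccc5ncccc5c4)n3c2)cc1F` carries 3,5-difluorophenyl in place of (dimethylamino)methyl on a saturated chain carbon bound to an amide-type nitrogen with 3,5-difluorophenyl in place of (dimethylamino)methyl on a saturated chain carbon bound to an amide-type nitrogen. For the measured compounds named here, only a 3.0-fold lower number from compound 2 to compound 3 (0.47 log units; beyond the scatter) bears on this change, and only indirectly, since no measured step varies this side chain. Part of that modest step is expected to be lost. The expected step is a 1.7-fold higher number from compound 3 to compound 4 (0.24 log units; within the scatter) and it points towards a higher number. Compound 4 is estimated at 85 nM with an expected range from 25 nM to 280 nM in this read-out.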

Compound 4, half-maximal inhibitory concentration: 53.6 nM
Compound 4: middle estimate off by 1.6-fold (0.20 log units), on the high side; the measured number falls inside the stated range.
By their numbers in this assay, from the lowest: compounds 3 and 4 (each within the scatter of the next); then compound 2.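

In this assay, the step of a 1.1-fold higher number from compound 3 to compound 4 (0.04 log units; within the scatter) shows that the dimethylamino nitrogen of compound 3 is not needed at this place: a 3,5-difluorophenyl, an aromatic ring of carbon only, leaves the two numbers indistinguishable. The gain over the nitrile also survives with this very different side chain, at a 2.7-fold lower number from compound 2 to compound 4 (0.43 log units; beyond the scatter). No measured property is available to account for this result.

Still open, as far as these compounds go, is how a carboxylic acid, a morpholine or a longer chain would fare on this amide. A single pair also cannot show how far this tolerance extends.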